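Amide Nitrogen Variation: Expectation for Compound 4

The source may report more compounds than this note shows. Statements on the series, on what has been measured and on what is new or still open speak of the compounds shown alone.

Three compounds sharing one core have been measured in a functional assay on A549 cells (Homo sapiens) for inhibition, read by MTT assay, with a stated time of 48 h; a lower number here means a stronger inhibitor, a higher number a weaker inhibitor:
compound 1, `COc1ccc(/C=C/c2cc(OC)cc(OC)c2/C=C/C(=O)N2CCN(C)CC2)cc1`, gives 4510 nM
compound 2, `COc1ccc(/C=C/c2cc(OC)cc(OC)c2/C=C/C(=O)N2CCCCC2C)cc1`, gives 5770 nM
compound 3, `COc1ccc(/C=C/c2cc(OC)cc(OC)c2/C=C/C(=O)N2CCC(c3ccccc3)CC2)cc1`, gives 6690 nM

Compound 3 stands among the others, since a 1.5-fold higher number from compound 1 to compound 3 (0.17 log units; within the scatter) and a 1.2-fold higher number from compound 2 to compound 3 (0.06 log units; within the scatter) both sit within the scatter, as does a 1.3-fold higher number from compound 1 to compound 2 (0.11 log units; within the scatter). Compound 4, `COc1ccc(/C=C/c2cc(OC)cc(OC)c2/C=C/C(=O)N(CC(C)C)CC(C)C)cc1`, differs from compound 3 by diisobutylamino in place of 4-phenylpiperidin-1-yl on a carbonyl carbon. The steps bearing on this change are the three amide swaps already seen, each within the scatter, so no step beyond the scatter is expected in this assay for compound 4. The estimate for compound 4 is 6000 nM, ranging from 2500 nM to 14000 nM. The expected step is therefore small: a 1.1-fold lower number from compound 3 to compound 4 (0.05 log units; within the scatter).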

Compound 4, half-maximal inhibitory concentration: 3350 nM
Estimate against measurement, compound 4: 1.8-fold (0.25 log units) above; the range from low to high includes it.
By their numbers in this assay, from the lowest: compounds 4, 1, 2 and 3 (each within the scatter of the next).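

In this assay this position accepts an open-chain group as well as the rings seen so far: diisobutylamino, which has no ring, gives a 2.0-fold lower number from compound 3 to compound 4 (0.30 log units; within the scatter) and also a 1.7-fold lower number from compound 2 to compound 4 (0.24 log units; within the scatter) and finally a 1.3-fold lower number from compound 1 to compound 4 (0.13 log units; within the scatter) with all three steps inside the scatter. Across these four compounds, a ring on the amide nitrogen is therefore not needed to keep the number in this range. Nothing shown explains this result. The compounds leave open whether an amide hydrogen, or a longer chain ending in an amine or a carboxylic acid, on this carbonyl carbon would also stay within the scatter.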